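Working notes: removing the chloro group from compound 3

The source may report more compounds than this note shows. Statements on the series, on what has been measured and on what is new or still open speak of the compounds shown alone.

Measured in a functional assay on HepG2 cells (Homo sapiens) for antiproliferative activity, read by MTT assay, with a stated time of 72 h; a lower number here means a stronger inhibitor, a higher number a weaker inhibitor:
compound 1 `O=C1COc2ccc(-c3cccc(NS(=O)(=O)c4ccc(F)cc4)c3)cc2N1`: > 40000 nM, a limit
compound 2 `COc1cccc(N2C(=O)COc3ccc(-c4cccc(NS(=O)(=O)c5ccc(F)cc5)c4)cc32)c1`: > 40000 nM, a limit
compound 3 `O=C1COc2ccc(-c3cccc(NS(=O)(=O)c4ccc(F)cc4)c3)cc2N1c1ccc(Cl)cc1`: 27800 nM

Compound 3 is the only one of the three to give a number rather than a limit. Compound 4 `O=C1COc2ccc(-c3cccc(NS(=O)(=O)c4ccc(F)cc4)c3)cc2N1c1ccccc1` differs from it by hydrogen in place of chloro on an aromatic carbon, so 4-chlorophenyl becomes phenyl. The closest measured changes are an at least 1.4-fold lower number from compound 1 to compound 3 (0.15 log units; that floor lies within the scatter) and an at least 1.4-fold lower number from compound 2 to compound 3 (0.15 log units; that floor lies within the scatter), while a step that the two limits leave unreadable from compound 1 to compound 2 gives no size. None isolates the chloro group. Resting on these steps, the expected change is a 1.3-fold higher number from compound 3 to compound 4 (0.11 log units; within the scatter), with no expected step beyond the scatter in this assay and any drift toward a higher number. For compound 4 the estimate is 36000 nM, with an expected range of 18000 nM to 60000 nM.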

Compound 4, half-maximal inhibitory concentration: 30300 nM
Beside the measured number, compound 4's estimate is 1.2-fold (0.07 log units) above it; low and high end bracket the measured number.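

Hydrogen in place of chloro gives a 1.1-fold higher number from compound 3 to compound 4 (0.04 log units; within the scatter), so a number rather than a limit does not depend on the chloro group: the plain phenyl of compound 4 gives one too. The other two new steps are an at least 1.3-fold lower number from compound 1 to compound 4 (0.12 log units; that floor lies within the scatter) and an at least 1.3-fold lower number from compound 2 to compound 4 (0.12 log units; that floor lies within the scatter), and both are floors. Neither gives a true size, because each starts from a limit of the assay: the limit of > 40000 nM in this assay, at which 2 of the 4 values shown sit.

Left open is how far compound 4 truly lies from compounds 1 and 2. Also open, from the compounds shown here alone, is whether an amine or a carboxylic acid in place of chloro on this ring would give a step beyond the scatter.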